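Fluoro for methoxy on the anilide of compound 3

A few compounds are considered here, and "the series" means these few. Any claim that something is new, unique, unknown or untested is made for them only; others in the source may bear on it.

In a physicochemical assay for lipophilicity, read by HPLC, in phosphate buffer, measured as chromatographic lipophilicity, at pH 7.4 (on this read-out lower numbers stand for lower lipophilicity and higher numbers for higher lipophilicity), compound 1 `COc1ccc2nc(C)cc(OCC(=O)Nc3cccc(C)c3)c2c1` gives 4.83, compound 2 `COc1ccc2nc(C)cc(OCC(=O)Nc3cc(C)ccc3C)c2c1` gives 5.05, and compound 3 `COc1ccc2nc(C)cc(OCC(=O)Nc3cc(C)c(OC)c(C)c3)c2c1` gives 4.99. Among the measured compounds shown here, compound 3 thus sits within the scatter of both compound 2 and compound 1, and the only step between neighbours that differ in one place, a number 0.22 log units higher from compound 1 to compound 2 (within the scatter), is likewise within the scatter. Compound 4 `COc1ccc2nc(C)cc(OCC(=O)Nc3cc(C)c(F)c(C)c3)c2c1` differs from compound 3 by fluoro in place of methoxy on an aromatic carbon. For the measured compounds named here, no measured pair exchanges a methoxy for a fluoro, so that one known step does not bear directly on this change; it shows only that a small change on the anilide ring moved this assay little. For compound 4 a step of a number 0.11 log units higher from compound 3 to compound 4 (within the scatter) is expected, not beyond the scatter. The estimate for compound 4 is 5.1, range 4.7 to 5.5.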

Compound 4, distribution coefficient: 5.5
Compound 4: the middle estimate sits 0.40 log units below what was measured; low and high end bracket the measured number.
By their numbers in this assay, from the lowest: compounds 1, 3 and 2 (each within the scatter of the next); then compound 4.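

In this assay, among the compounds shown here, fluoro in place of methoxy on the aromatic carbon ortho to two methyl groups gives a number 0.51 log units higher from compound 3 to compound 4 (beyond the scatter) and so moves the read-out at this position, while the one earlier step stayed within the scatter. The exchanges of the whole anilide show the same separation, with a number 0.45 log units higher from compound 2 to compound 4 (beyond the scatter) and a number 0.67 log units higher from compound 1 to compound 4 (beyond the scatter) setting compound 4 apart from the other three compounds. No measurement available here explains this step.

Open, from the compounds shown here alone, is how a chloro, an amine or a carboxylic acid at this position would read. Also open, going by these compounds, is whether the step from methoxy to fluoro holds without the two methyl groups.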